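This account rests on a few compounds, and the source may have more. Where it says the series, first, only, none or still open, it means among the compounds named here.

Measured so far in a functional assay on HT-29 cells (Homo sapiens) for cytotoxicity, read by MTT assay, with a stated time of 72 h; on this read-out lower numbers stand for stronger inhibition and higher numbers for weaker inhibition
- compound 1 `Cc1ccc(NC(=O)CN2CCN(c3nnc(Cc4ccncc4)c4ccccc34)CC2)c(C)c1` gives 1930 nM
- compound 2 `O=C(CN1CCN(c2nnc(Cc3ccccc3)c3ccccc23)CC1)Nc1ccc(F)c(F)c1` gives 9510 nM
- compound 3 `O=C(CN1CCN(c2nnc(Cc3ccncc3)c3ccccc23)CC1)Nc1ccc(F)c(Cl)c1` gives 880 nM

Compound 3 has the lowest of the three numbers, which makes it the strongest inhibitor here. Compound 4 `O=C(CN1CCN(c2nnc(Cc3ccncc3)c3ccccc23)CC1)Nc1ccc(F)c(F)c1` differs from it by one swap (fluoro in place of chloro on an aromatic carbon): fluoro in place of chloro on an aromatic carbon, turning 3-chloro-4-fluorophenyl into 3,4-difluorophenyl.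

For the measured compounds named here, no measured step shows this exact swap. The closest evidence is a 2.2-fold lower number from compound 1 to compound 3 (0.34 log units; beyond the scatter) on replacing a whole 2,4-dimethylphenyl with 3-chloro-4-fluorophenyl, and that larger change gave only a modest step. Compound 2 also carries 3,4-difluorophenyl and gives 9510 nM as the highest number, but it differs from compound 4 elsewhere, so it is only a weak hint. A modest move toward a higher number, meaning weaker inhibition, therefore seems likely. The expected step is a 1.7-fold higher number from compound 3 to compound 4 (0.23 log units; within the scatter) in this estimate. Compound 4 is estimated at 1500 nM with an expected range from 600 nM to 4000 nM in this assay when tested.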

Compound 4, half-maximal inhibitory concentration: 2320 nM
The estimate for compound 4 lay 1.5-fold (0.19 log units) below the measured number; the range from low to high includes it.
By their numbers in this assay, from the lowest: compound 3; then compounds 1 and 4 (each within the scatter of the next); then compound 2.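

In this assay, fluoro in place of chloro on an aromatic carbon, ortho to a fluoro group, gives a 2.6-fold higher number from compound 3 to compound 4 (0.42 log units; beyond the scatter) with the rest of the molecule unchanged, so a swap of one atom at this position is enough to move the number beyond the scatter. Compound 4 also isolates a second site, since pyridin-4-yl in place of phenyl alone gives a 4.1-fold lower number from compound 2 to compound 4 (0.61 log units; beyond the scatter) when the 3,4-difluorophenyl is kept. Replacing 2,4-dimethylphenyl with 3,4-difluorophenyl gives a 1.2-fold higher number from compound 1 to compound 4 (0.08 log units; within the scatter), which stays within the scatter, whereas 3-chloro-4-fluorophenyl gave a step beyond it.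

No measurement given here explains the difference between chloro and fluoro at this position. Going by these compounds, whether bromo, methyl or methoxy at the same position would give a lower or a higher number also remains open.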